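This account rests on a few compounds, and the source may have more. Where it says the series, first, only, none or still open, it means among the compounds named here.

Compound 1 `O=C(COCc1ccccc1)N1CCN(c2ccccn2)CC1` is measured in a functional assay on HEK293 cells for positive allosteric modulation of metabotropic glutamate receptor 5 (Rattus norvegicus), read by fluorescence and calcium flux (a lower number here means that less compound is needed, a higher number that more compound is needed for the effect), and gives 5400 nM. Compound 2 `O=C(COCc1ccccc1)N1CCN(c2cccnc2)CC1` carries a pyridin-3-yl in place of the pyridin-2-yl of compound 1; in this assay compound 2 is reported as "not active" (no number reported), so it stands without any number in this assay. Compound 3 `O=C(COCc1ccccc1)N1CCN(c2nccs2)CC1` differs from compound 2 by 1,3-thiazol-2-yl in place of pyridin-3-yl on an amine nitrogen in a ring. For the measured compounds named here, no measured step of this kind exists here, so the direction and size of the change can only be guessed. For compound 3 in this assay the expected value is 8000 nM, with a range from 2000 nM to 40000 nM.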

Compound 3, half-maximal effective concentration: > 10000 nM
Compound 3 was reported as a limit (the forecaster's own chance of this, stated with the estimate: 50%); middle value at least 1.2-fold (0.09 log units) from the limit.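

In this assay compound 3 gives > 10000 nM, which is a limit of the assay and not a number. Placing 1,3-thiazol-2-yl instead of pyridin-2-yl on an amine nitrogen in a ring gives an at least 1.8-fold higher number from compound 1 to compound 3 (0.26 log units; that floor lies within the scatter), so this five-membered ring brings no sign of a lower number than compound 1. As far as these compounds go, the full size of that step stays unknown because the reading stops at a limit: the limit of > 10000 nM in this assay, at which 1 of the 3 values shown sits. The step from compound 2 cannot be read, since compound 2 has no number. Open, from the compounds shown here alone, is whether a plain phenyl or a pyridin-4-yl at this position, or a methyl group on the pyridin-2-yl, would give a lower number than compound 1.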